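One ring swap and the expected effect on cell growth

The compounds below may be only part of what the source reports. "The series", "measured", "known", "first", "only" and "open" are said of these compounds alone.

Among the measured compounds shown here, in a functional assay on HepG2 cells (Homo sapiens) for antiproliferative activity, read by sulforhodamine B assay, with a stated time of 48 h (a lower number here means a stronger inhibitor, a higher number a weaker inhibitor), compound 1 (`COc1cc(C=C(C(=O)/C=C/c2cccc(OC)c2OC)C(=O)/C=C/c2cccc(OC)c2OC)ccc1O`) gives 200 nM and compound 2 (`COc1ccc(C=C(C(=O)/C=C/c2cccc(OC)c2OC)C(=O)/C=C/c2cccc(OC)c2OC)cc1OC`) gives 200 nM as well, so compound 1 stands level with its only measured neighbour. Compound 3 (`COc1cccc(C=C(C(=O)/C=C/c2cccc(OC)c2OC)C(=O)/C=C/c2cccc(OC)c2OC)c1OC`) has not yet been measured. It differs from compound 1 by 2,3-dimethoxyphenyl in place of 4-hydroxy-3-methoxyphenyl on a double-bonded chain carbon bound to a double-bonded chain carbon. For the measured compounds named here, compound 3 has no hydrogen-bond donor in this group, yet no measured compound carries 2,3-dimethoxyphenyl in this place, so the guide is thin. Going by the values given here, the only measured step that bears on this, with methyl in place of hydrogen on an oxygen on an aromatic ring, is no change at the digits printed from compound 1 to compound 2 (within the scatter) and so no change beyond the scatter is expected in this assay. That makes no change at the digits printed from compound 1 to compound 3 (within the scatter) the expected step. For compound 3 the expected value is 200 nM and the estimated range runs from 90 nM to 450 nM around it.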

Compound 3, half-maximal inhibitory concentration: 230 nM
Beside the measured number, compound 3's estimate is 1.2-fold (0.06 log units) below it; low and high end bracket the measured number.
By their numbers in this assay, from the lowest: compounds 1, 2 and 3 (each within the scatter of the next).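

In this assay, the swap of 4-hydroxy-3-methoxyphenyl for 2,3-dimethoxyphenyl gives a 1.2-fold higher number from compound 1 to compound 3 (0.06 log units; within the scatter), and the swap of 3,4-dimethoxyphenyl for the same group gives a 1.2-fold higher number from compound 2 to compound 3 (0.06 log units; within the scatter). The earlier pair showed only that methyl could replace the hydrogen on the ring oxygen, whereas these steps show that rearranging the methoxy groups on this ring, as the names 3,4-dimethoxyphenyl and 2,3-dimethoxyphenyl record, also leaves the number within the scatter. Nothing available explains why these three groups read alike.

As far as these compounds go, all three groups at this place are phenyl rings carrying oxygen substituents, so it remains open whether an amine, a carboxylic acid or a bare phenyl ring would read the same. The rest of the core is identical across these compounds, so they say nothing about changes made there.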